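Swapping the acetyl on the piperazine nitrogen for a dichlorophenyl

The source may hold more compounds than are shown below. What is called first, only, known or untested is meant among the compounds shown, and "the series" means these compounds.

Measured compounds in a functional assay on DU-145 cells (Homo sapiens) for cytotoxicity, read by sulforhodamine B assay, with a stated time of 48 h; on this read-out higher numbers stand for weaker inhibition of growth and lower numbers for stronger inhibition of growth:
compound 1 `N#Cc1ccc(Nc2nc(Oc3ccnc4ccccc34)nc(N3CCN(c4ccccc4)CC3)n2)cc1C(F)(F)F`: > 100000 nM
compound 2 `N#Cc1ccc(Nc2nc(Oc3ccnc4ccccc34)nc(N3CCN(c4ncccn4)CC3)n2)cc1C(F)(F)F`: 85200 nM
compound 3 `CC(=O)N1CCN(c2nc(Nc3ccc(C#N)c(C(F)(F)F)c3)nc(Oc3ccnc4ccccc34)n2)CC1`: 75100 nM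

The value of compound 1 is a limit of the assay, not a number. Among the two numbers available, compound 3 holds the lowest, and its nearest neighbour is compound 2, which lies within the scatter of it. The new compound, compound 4 `N#Cc1ccc(Nc2nc(Oc3ccnc4ccccc34)nc(N3CCN(c4cccc(Cl)c4Cl)CC3)n2)cc1C(F)(F)F`, differs from compound 3 in one place: 2,3-dichlorophenyl in place of acetyl on an amine nitrogen in a ring.

Within the data shown here, two measured steps touch the same ring nitrogen. The step of an at least 1.3-fold lower number from compound 1 to compound 3 (0.12 log units; that floor lies within the scatter) exchanged phenyl for acetyl and is bounded only by the limit (the limit of > 100000 nM in this assay, at which 1 of the 3 values shown sits); the step of a 1.1-fold lower number from compound 2 to compound 3 (0.05 log units; within the scatter) exchanged pyrimidin-2-yl for acetyl and sits within the scatter. Among the measured compounds shown here, compound 4 goes the other way, putting an aromatic ring back where compound 3 carries acetyl, and so the nearest precedent is compound 1, whose value is a limit. Compound 4 is therefore expected to return a higher number than compound 3, or again a limit, with the step of a 1.3-fold higher number from compound 3 to compound 4 (0.12 log units; within the scatter) estimated. The value of compound 4 is expected to be 100000 nM, in the range 40000 nM to 250000 nM.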

Compound 4, concentration for 50% growth inhibition: > 100000 nM
Compound 4 gave a limit, no number; the forecaster's own chance of this, stated with the estimate: 50%; the middle value lies on the limit itself.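

In this assay compound 4 gives > 100000 nM, which is a limit of the assay and not a number. The steps to it, an at least 1.3-fold higher number from compound 3 to compound 4 (0.12 log units; that floor lies within the scatter) and an at least 1.1-fold higher number from compound 2 to compound 4 (0.06 log units; that floor lies within the scatter), are floors only, so this change shows no separation from either compound beyond the scatter. What is new is that the 2,3-dichlorophenyl group joins the phenyl group of compound 1 at the limit, so placing chlorine on the phenyl ring at this nitrogen yields no number, and the steps between the two compounds cannot be read, although compound 2, with its pyrimidin-2-yl ring, goes against any rule that aromatic rings here end at the limit: the limit of > 100000 nM in this assay, at which 2 of the 4 values shown sit.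

The compounds shown leave open how far compound 1 and compound 4 actually lie from each other, and whether a single chlorine on the phenyl ring would behave like the pair. They also leave open whether a benzyl group, a hydroxyethyl chain or a free amine on this ring nitrogen would give a number well below those of compound 2 and compound 3.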